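Swapping butylsulfanyl for propylamino on a purine-like core

A few compounds are considered here, and "the series" means these few. Any claim that something is new, unique, unknown or untested is made for them only; others in the source may bear on it.

The measured compounds:
- compound 1, `CCOc1nc(N)c2nc(O)n(Cc3ccccc3)c2n1`: 0.1 uM
- compound 2, `CCCCSc1nc(N)c2nc(O)n(Cc3ccccc3)c2n1`: 0.01 uM
- compound 3, `Nc1ncnc2c1nc(O)n2-c1ccccc1`: > 10 uM

In a functional assay (spleen, spleen) for activation, with Mus musculus as the target (a higher number here means that more compound is needed for the effect, a lower number that less compound is needed), compound 2 gives the lowest number of the two numbers available, and its nearest neighbour is compound 1 at 0.1 uM. Compound 3 sits at the limit of this assay, > 10 uM, so no number is known for it (the limit of > 10 uM in this assay, at which 1 of the 3 values shown sits).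

The new compound is compound 4, `CCCNc1nc(N)c2nc(O)n(Cc3ccccc3)c2n1`. Its difference from compound 2 is propylamino in place of butylsulfanyl on an aromatic carbon. Within the data shown here, the only measured step that bears on this position is a 10-fold lower number from compound 1 to compound 2 (1.00 log units; beyond the scatter), which shows that exchanging the group on this aromatic carbon can shift the number by a clear margin. Compound 4 keeps the same benzyl-bearing core as compound 2 and changes only the chain at that carbon, so a step of moderate size, in either direction, is plausible. Among the measured compounds shown here, since the butylsulfanyl of compound 2 gave the best number so far, a modest move towards a higher number is expected, a 3.0-fold higher number from compound 2 to compound 4 (0.48 log units; beyond the scatter). For compound 4 the estimate in this assay is therefore 0.03 uM, with a range from 0.005 uM to 0.2 uM.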

Compound 4, minimum effective concentration: 0.1 uM
For compound 4 the middle estimate is 3.3-fold (0.52 log units) below the measured one; the measured number falls inside the stated range.
By their numbers in this assay, from the lowest: compound 2; then compounds 1 and 4 (each within the scatter of the next). At a limit, above all of these: compound 3.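

In this assay, propylamino in place of butylsulfanyl gives a 10-fold higher number from compound 2 to compound 4 (1.00 log units; beyond the scatter) and so shows that this aromatic carbon responds to a second kind of exchange, not only to the one seen earlier. Propylamino in place of ethoxy gives no change at the digits printed from compound 1 to compound 4 (within the scatter) at the same position, so the oxygen-linked and nitrogen-linked chains cannot be told apart here, while the butylsulfanyl of compound 2 stands apart from both with the lowest number among these three benzyl-bearing compounds. No measurement shown offers a reason for these steps.

The exchange from butylsulfanyl to propylamino alters both the linking atom and the chain, so the compounds shown cannot say which of the two accounts for the step. Butylamino and propylsulfanyl on the same carbon would pull these two changes apart, and butoxy would extend the same comparison to an oxygen-linked chain of matching length.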